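Cyclohexyl for Cyclopropyl on the Alkyne of a Uridine Analogue

The source may hold more compounds than are shown below. What is called first, only, known or untested is meant among the compounds shown, and "the series" means these compounds.

Of the compounds shown here, three have been measured in an ADME assay on MRC5 cells (Homo sapiens) for cytotoxicity, read by MTT assay; on this read-out higher numbers stand for lower toxicity in this test and lower numbers for higher toxicity in this test. Compound 1 `CCCCCCC#Cc1cn([C@@H]2O[C@H](CO)[C@@H](O)[C@H]2O)c(=O)[nH]c1=O` gives 15700 nM, compound 2 `O=c1[nH]c(=O)n([C@@H]2O[C@H](CO)[C@@H](O)[C@H]2O)cc1C#CC1CC1` gives 24200 nM, and compound 3 `CCC#Cc1c[nH]c(=O)[nH]c1=O`, which lacks the sugar, gives 120000 nM. Compound 2 thus holds the second highest of the three numbers; its nearest neighbour is compound 1, and the gap to compound 3 is the widest. Among the measured compounds shown here, the one step between compounds differing in a single place is a 1.5-fold higher number from compound 1 to compound 2 (0.19 log units; within the scatter).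

Compound 4 `O=c1[nH]c(=O)n([C@@H]2O[C@H](CO)[C@@H](O)[C@H]2O)cc1C#CC1CCCCC1` is not yet measured. Relative to compound 2 it carries cyclohexyl in place of cyclopropyl on a triple-bonded carbon. For the measured compounds named here, the only step that bears on this change is the one from compound 1 to compound 2, which lay within the scatter, and compound 4 sits between those two in the size of its ring. No step beyond the scatter is therefore expected in this assay; the estimate is a 1.3-fold lower number from compound 2 to compound 4 (0.13 log units; within the scatter). Compound 4 is expected to give about 18000 nM, within a range from 9000 nM to 36000 nM.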

Compound 4, half-maximal cytotoxic concentration: 36800 nM
Compound 4: middle estimate off by 2.0-fold (0.31 log units), on the low side; the measured number lies above the stated range.
By their numbers in this assay, from the lowest: compounds 1, 2 and 4 (each within the scatter of the next, the first and the last beyond it); then compound 3.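

In this assay, cyclohexyl in place of cyclopropyl on a triple-bonded carbon gives a 1.5-fold higher number from compound 2 to compound 4 (0.18 log units; within the scatter) and so does not separate the two rings at this position. Cyclohexyl in place of hexyl gives a 2.3-fold higher number from compound 1 to compound 4 (0.37 log units; beyond the scatter) and is the first step at this position to pass the scatter, although only modestly, so here the ring and the open chain can be told apart. Nothing among the data shown accounts for either step.

Every group shown on this triple-bonded carbon consists of carbon alone and carries no aromatic ring, so how an amine, a carboxylic acid or a phenyl ring would read there remains open. Also open, as far as these compounds go, is whether these steps would hold on any other cell line.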